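Adding a Diisopropylamino Group to Compound 1

The compounds below may be only part of what the source reports. "The series", "measured", "known", "first", "only" and "open" are said of these compounds alone.

For the measured compounds named here, the compounds measured so far are these. Compound 1 `CCN1CCN(CCC(=O)Nc2nc3c(C)cccc3s2)CC1` gives 543 nM in an assay on membranes from brain for displacement of a labelled ligand from Sigma non-opioid intracellular receptor 1 (Cavia porcellus), read by scintillation counting, with a stated time of 120 min; a lower number here means a stronger inhibitor, a higher number a weaker inhibitor. Compound 2 `Cc1cccc2sc(NC(=O)CCN3CCN(CCCN(C)C)CC3)nc12` gives 570 nM. Compound 3 `Cc1cccc2sc(NC(=O)CCN3CCN(C4CCCCC4)CC3)nc12` gives 24 nM.

Compound 1 stands second highest of the three numbers. Its nearest neighbour is compound 2, a 1.0-fold higher number from compound 1 to compound 2 (0.02 log units; within the scatter), and its furthest is compound 3, a 23-fold lower number from compound 1 to compound 3 (1.35 log units; beyond the scatter). The change to compound 2 was (dimethylamino)methyl in place of hydrogen on a saturated chain carbon, two bonds along the chain from an amine nitrogen in a ring; the change to compound 3 was cyclohexyl in place of ethyl on an amine nitrogen in a ring.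

Compound 4 `Cc1cccc2sc(NC(=O)CCN3CCN(CCN(C(C)C)C(C)C)CC3)nc12` has not been measured yet. Its difference from compound 1 is diisopropylamino in place of hydrogen on a saturated chain carbon, two bonds along the chain from an amine nitrogen in a ring. The step that bears on it most directly is a 1.0-fold higher number from compound 1 to compound 2 (0.02 log units; within the scatter), where another amino group entered at the same kind of place and the number barely moved. The large drop a 23-fold lower number from compound 1 to compound 3 (1.35 log units; beyond the scatter) came from a change on the amine nitrogen in the ring itself, which compound 4 keeps as in compound 1. A small step toward a lower number, or none beyond the scatter, is therefore expected: a 1.8-fold lower number from compound 1 to compound 4 (0.26 log units; within the scatter). Compound 4 is estimated at 300 nM, with a likely range from 100 nM to 1200 nM.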

Compound 4, inhibition constant: 809 nM
For compound 4 the middle estimate is 2.7-fold (0.43 log units) below the measured one; measured number inside the range.
By their numbers in this assay, from the lowest: compound 3; then compounds 1, 2 and 4 (each within the scatter of the next).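

In this assay, the 7 heavy atoms of diisopropylamino enter on a saturated chain carbon, two bonds along the chain from an amine nitrogen in a ring, with no shift beyond the scatter (a 1.5-fold higher number from compound 1 to compound 4 (0.17 log units; within the scatter)). Replacing (dimethylamino)methyl with diisopropylamino at this place also stays within the scatter (a 1.4-fold higher number from compound 2 to compound 4 (0.15 log units; within the scatter)), so compounds 1, 2 and 4 cannot be separated even though their amino groups differ, and two different amino-bearing chains now behave alike here. A large gap remains (a 34-fold higher number from compound 3 to compound 4 (1.53 log units; beyond the scatter)), which leaves compound 3, with cyclohexyl on the amine nitrogen in a ring, as the strongest inhibitor of the four and shows that adding a larger amino group to the chain does not reach what that change achieved.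

Nothing measured here explains why these numbers fall as they do. Still open, on these data alone, is whether a hydroxyl or a carboxylic acid at this chain position would behave like these amino groups, and whether a benzyl group on the amine nitrogen in a ring would match cyclohexyl.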